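The source may hold more compounds than are shown below. What is called first, only, known or untested is meant among the compounds shown, and "the series" means these compounds.

Compound 2 `Cc1c(Cc2ccccc2)c(=O)oc2cc(OCC(O)CNc3nccs3)ccc12` carries a 1,3-thiazol-2-yl group on an amine nitrogen, with the rest of the molecule shared across the small series. In an ADME assay on A549 cells (Homo sapiens) for cytotoxicity, read by CellTiter-Glo (on this read-out higher numbers stand for lower toxicity in this test and lower numbers for higher toxicity in this test), compound 2 gives 93000 nM. Among the measured compounds shown here, the only other measured member, compound 1 `C#CCNCC(O)COc1ccc2c(C)c(Cc3ccccc3)c(=O)oc2c1`, has a propargyl group at that same nitrogen and gives 95500 nM in this assay; the two numbers are indistinguishable within the scatter, and the step of a 1.0-fold lower number from compound 1 to compound 2 (0.01 log units; within the scatter) reflects that.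

Compound 3 `Cc1c(Cc2ccccc2)c(=O)oc2cc(OCC(O)CNc3nc4ccccc4[nH]3)ccc12` is the next member, and it differs from compound 2 by 1H-benzimidazol-2-yl in place of 1,3-thiazol-2-yl on an amine nitrogen. For the measured compounds named here, the one measured step that bears on this change is the swap at the same amine nitrogen from compound 1 to compound 2, which moved the number by a 1.0-fold lower number from compound 1 to compound 2 (0.01 log units; within the scatter), so that exchanging one nitrogen substituent for another left this assay unchanged beyond the scatter. On that basis the expected step from compound 2 to compound 3 is a 1.0-fold lower number from compound 2 to compound 3 (0.01 log units; within the scatter), with no direction beyond the scatter. Compound 3 is therefore estimated at 90000 nM in this assay, with a range from 40000 nM to 200000 nM.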

Compound 3, half-maximal cytotoxic concentration: > 100000 nM
Compound 3 was reported as a limit (the forecaster's own chance of this, stated with the estimate: 25%); at least 1.1-fold (0.04 log units) between middle value and limit.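

In this assay compound 3 is reported only as a limit of the assay, > 100000 nM, and not as an exact number. That limit gives only minimum sizes for the two new steps, an at least 1.0-fold higher number from compound 2 to compound 3 (0.03 log units; that floor lies within the scatter) and an at least 1.0-fold higher number from compound 1 to compound 3 (0.01 log units; that floor lies within the scatter), so neither step can be said to exceed the scatter. The earlier swap of propargyl for 1,3-thiazol-2-yl did not show what happens with a six-membered aromatic ring of carbon only and a hydrogen-bond donor in the group on this amine nitrogen; with 1H-benzimidazol-2-yl there, the number does not drop, so this test gives no sign of higher toxicity, though the true value remains unknown: the limit of > 100000 nM in this assay, at which 1 of the 3 values shown sits.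

The compounds shown leave open whether any group on this amine nitrogen can bring the number down, for example a morpholine ring, a carboxylic acid or a longer saturated chain. They also cannot separate the part played by the nitrogen substituent from that of the shared core, which is the same in all of them.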